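Amide variation on the shared core: colon cell toxicity

This account rests on a few compounds, and the source may have more. Where it says the series, first, only, none or still open, it means among the compounds named here.

Compound 1 `COc1cc(-c2nn(-c3cccc(NC(=O)c4cccc(C(F)(F)F)c4)c3)cc2-c2ccncc2)ccc1Cl` in a functional assay on HT-29 cells (Homo sapiens) for inhibition, read by sulforhodamine B assay, with a stated time of 48 h (on this read-out higher numbers stand for lower toxicity in this test and lower numbers for higher toxicity in this test), gives > 50000 nM, a limit of the assay.
Compound 2 `COc1cc(-c2nn(-c3cccc(NC(=O)Nc4ccc(Cl)c(Cl)c4)c3)cc2-c2ccncc2)ccc1Cl` in this assay gives > 50000 nM, also a limit.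
Compound 3 `COc1cc(-c2nn(-c3cccc(NC(=O)c4ccc(Cl)c(C(F)(F)F)c4)c3)cc2-c2ccncc2)ccc1Cl` in this assay gives > 32500 nM, again a limit.

Compound 3 thus stands only at a limit, as do the other two values, and the steps a step that the two limits leave unreadable from compound 1 to compound 2, a step that the two limits leave unreadable from compound 1 to compound 3 and a step that the two limits leave unreadable from compound 2 to compound 3 are all unreadable; the two limits the limit of > 32500 nM in this assay, at which 1 of the 3 values shown sits, and the limit of > 50000 nM in this assay, at which 2 of the 3 values shown sit, are the whole of what is known. Compound 4 `COc1cc(-c2nn(-c3cccc(NC(=O)c4ccccc4)c3)cc2-c2ccncc2)ccc1Cl` differs from compound 3 by phenyl in place of 4-chloro-3-(trifluoromethyl)phenyl on a carbonyl carbon. The measured steps that touch the same carbonyl carbon or its aryl ring give no readable size in either direction, so no step beyond the scatter can be expected in this assay. For compound 4 a value at the limit is again expected, 50000 nM, estimated between 25000 nM and 100000 nM. The step this estimate means is a step that the limit leaves unreadable from compound 3 to compound 4.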

Compound 4, concentration lethal to 50% of the cells: > 100000 nM
Compound 4 ended at the assay's limit; the forecaster's own chance of this, stated with the estimate: 80%; middle value at least 2.0-fold (0.30 log units) away from the limit.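

In this assay compound 4 gives > 100000 nM, a limit. Its steps to compounds 1, 2 and 3 cannot be read, as all four values are limits. Whether any of these compounds has a measurable lethal concentration in this assay stays open.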